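This account rests on a few compounds, and the source may have more. Where it says the series, first, only, none or still open, it means among the compounds named here.

Compound 3 `CC(=O)/C(=N\c1ccccc1)NNc1ccccc1C` and compound 4 `CC(=O)/C(=N\c1ccccc1)NNc1ccccc1C(F)(F)F` share one core; compound 1 `CC(=O)/C(=N\Nc1ccccc1C(F)(F)F)Oc1cccc(Cl)c1` and compound 2 `CC(=O)/C(=N\Nc1ccccc1C)Oc1cccc(Cl)c1` share another, and how the two cores differ is not broken down here. In an assay on isolated protein for binding affinity to corticotropin-releasing factor receptor 1 (Homo sapiens) (a higher number here means a weaker inhibitor, a lower number a stronger inhibitor), compound 3 gives 526 nM. For compound 2 in this assay the result is a limit of the assay, > 10000 nM. For compound 1 in this assay the result is likewise a limit, > 10000 nM. The step that the two limits leave unreadable from compound 2 to compound 1, made by the change (trifluoromethyl in place of methyl on an aromatic carbon), therefore cannot be read, since both values sit at the limit of > 10000 nM in this assay, at which 2 of the 3 values shown sit. The change from compound 3 to compound 4 is the same, (trifluoromethyl in place of methyl on an aromatic carbon), but here it is made on a core that yields a number. With the earlier step unreadable, the expectation rests on compound 3 at 526 nM. For compound 4 a step of a 1.3-fold higher number from compound 3 to compound 4 (0.12 log units; within the scatter) is expected. Compound 4 is thus estimated at 700 nM, between 200 nM and 3000 nM.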

Compound 4, inhibition constant: 2260 nM
Compound 4: middle estimate off by 3.2-fold (0.51 log units), on the low side; the measured number falls inside the stated range.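

In this assay, trifluoromethyl in place of methyl on an aromatic carbon gives a 4.3-fold higher number from compound 3 to compound 4 (0.63 log units; beyond the scatter), so on this core the change costs a modest amount of binding. On the other core the same change cannot be read, since compound 2 and compound 1 both sit at a limit of the assay: the limit of > 10000 nM in this assay, at which 2 of the 4 values shown sit. The series therefore offers one readable step on one core, which shows neither that the change carries over to the other core nor that it fails to.

The compounds shown leave open how a chlorine, a methoxy group or an amine at this place on the aromatic ring would compare with methyl and trifluoromethyl. They also leave open whether any such group would bring the core of compound 1 to a readable number.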